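The compounds below may be only part of what the source reports. "The series", "measured", "known", "first", "only" and "open" are said of these compounds alone.

Compound 1 `CS(=O)(=O)c1ccc(Nc2ncnc3sc(Nc4c(Cl)cccc4Cl)nc23)cc1` carries a methylsulfonyl group on its outer ring, and in a functional assay on HEK293 cells for antagonist activity at transient receptor potential cation channel subfamily V member 1 (Homo sapiens), read by calcium flux (a lower number here means a stronger inhibitor, a higher number a weaker inhibitor), compound 1 gives 5 nM. Compound 2 `O=C(O)c1ccc(Nc2ncnc3sc(Nc4c(Cl)cccc4Cl)nc23)cc1` carries a carboxy group in that same place. In this assay compound 2 reaches only the limit of > 5000 nM, not a measured number. Among the measured compounds shown here, the swap an at least 1000-fold higher number from compound 1 to compound 2 (3.00 log units; beyond the scatter) is the single measured step so far, and compound 2 thus stands at the weak end of the two values, sitting at the limit of > 5000 nM in this assay, at which 1 of the 2 values shown sits. Compound 3 `O=C(c1ccc(Nc2ncnc3sc(Nc4c(Cl)cccc4Cl)nc23)cc1)N1CCCC1` differs from compound 2 by pyrrolidin-1-yl in place of hydroxy on a carbonyl carbon, so the acid becomes a pyrrolidine amide. For the measured compounds named here, only the step from compound 1 to compound 2 bears on this change, and it was large; replacing the acid is expected to bring the number down substantially, though not necessarily all the way back to compound 1. Compound 3 is therefore estimated at 100 nM, within 10 nM to 1500 nM, an expected step of an at least 50-fold lower number from compound 2 to compound 3 (1.69 log units; beyond the scatter).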

Compound 3, half-maximal inhibitory concentration: > 5000 nM
Compound 3: a limit, no number; the forecaster's own chance of this, stated with the estimate: 10%; at least 50-fold (1.69 log units) between middle value and limit.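

In this assay compound 3 gives > 5000 nM, which is a limit and not a number. Changing the group on this aromatic carbon to (pyrrolidin-1-yl)carbonyl gives an at least 1000-fold higher number from compound 1 to compound 3 (3.00 log units; beyond the scatter), so a carbonyl-linked group without the hydroxy also leaves the compound far weaker than the methylsulfonyl compound. The step between the acid and the amide cannot be read, because both compounds rest at the same limit: the limit of > 5000 nM in this assay, at which 2 of the 3 values shown sit.

Going by these compounds, how far either compound lies past that limit stays open, and so does any difference between them. Also open, on these data alone, is whether a sulfonamide or a methyl ketone on this aromatic carbon would bring the number back towards compound 1 and its 5 nM.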